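Swapping Chloro for Bromo on a Sulfonyl Aryl Ring

A few compounds are considered here, and "the series" means these few. Any claim that something is new, unique, unknown or untested is made for them only; others in the source may bear on it.

The measured compounds and their values:

Compound 1, `Cc1ccc(-c2nn(-c3ccccc3)cc2-c2nc3ccccc3n2S(=O)(=O)c2ccc(Cl)cc2)cc1`: in an ADME assay on cells (Hepatocyte, Mus musculus) for cytotoxicity, read by MTT assay, with a stated time of 24 h (a higher number here means that more compound is tolerated, a lower number that less compound is tolerated), compound 1 gives 216000 nM.
Compound 2, `Cc1ccc(-c2nn(-c3ccccc3)cc2-c2nc3ccccc3n2S(=O)(=O)c2ccc(Br)cc2)cc1`: compound 2 reaches only a limit of this assay, > 300000 nM, not a number.
Compound 3, `O=S(=O)(c1ccc(Cl)cc1)n1c(-c2cn(-c3ccccc3)nc2-c2ccc(C(F)(F)F)cc2)nc2ccccc21`: in this assay compound 3 gives 173000 nM.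

Compound 1 and compound 2 differ in one place, (bromo in place of chloro on an aromatic carbon). This change made a step of an at least 1.3-fold higher number from compound 1 to compound 2 (0.14 log units; that floor lies within the scatter), and the only fact bearing on it is the limit of > 300000 nM in this assay, at which 1 of the 3 values shown sits. Compound 1 and compound 3 differ in another place, (trifluoromethyl in place of methyl on an aromatic carbon), and that step was a 1.2-fold lower number from compound 1 to compound 3 (0.10 log units; within the scatter).

Compound 4, `O=S(=O)(c1ccc(Br)cc1)n1c(-c2cn(-c3ccccc3)nc2-c2ccc(C(F)(F)F)cc2)nc2ccccc21`, has not yet been measured. It stands to compound 3 as compound 2 stands to compound 1: the difference is bromo in place of chloro on an aromatic carbon, and the place is the same in its every word, so this is the same change seen once before among these compounds.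

The earlier step from compound 1 to compound 2 reached a limit of this assay, so its true size is not known beyond its floor. On that basis a step of a 1.4-fold higher number from compound 3 to compound 4 (0.14 log units; within the scatter) is expected from compound 3 to compound 4, with a real chance that compound 4 too reports only a limit. Compound 4 is therefore estimated at 240000 nM, within a range from 130000 nM to 420000 nM.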

Compound 4, half-maximal cytotoxic concentration: 167000 nM
For compound 4 the middle estimate is 1.4-fold (0.16 log units) above the measured one; the measured number falls inside the stated range.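

In this assay, bromo in place of chloro gave a 1.0-fold lower number from compound 3 to compound 4 (0.02 log units; within the scatter), and trifluoromethyl in place of methyl gave an at least 1.7-fold lower number from compound 2 to compound 4 (0.25 log units; that floor lies within the scatter). These results do not show that the bromo change carries over from one core to the other with the same size, nor do they show that its size differs, as the two cases set side by side make plain: the same change on two cores in this assay, an at least 1.3-fold higher number (0.14 log units; that floor lies within the scatter) from compound 1 to compound 2 and a 1.0-fold lower number (0.02 log units; within the scatter) from compound 3 to compound 4; the limit leaves it open whether they differ. The trifluoromethyl change stays just as undecided, so no size can yet be assigned to it that would hold on both cores: the same change on two cores in this assay, a 1.2-fold lower number (0.10 log units; within the scatter) from compound 1 to compound 3 and an at least 1.7-fold lower number (0.25 log units; that floor lies within the scatter) from compound 2 to compound 4; the limit leaves it open whether they differ.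

As far as these compounds go, the true value of compound 2 stays open, since it is known only as a limit and not as a number: the limit of > 300000 nM in this assay, at which 1 of the 4 values shown sits. Also open, from the compounds shown here alone, is how a fluoro, a methoxy or an amine in place of the bromo on the 4-bromophenyl ring would read in this assay, and whether any such group would move the number beyond the usual scatter.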